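Heptyl to ethoxycarbonyl: a para swap on the urea

The source may hold more compounds than are shown below. What is called first, only, known or untested is meant among the compounds shown, and "the series" means these compounds.

Measured so far:
compound 1, `CCCCCc1ccc(NC(=O)N[C@H](C)c2ccccc2)cc1`, 101%
compound 2, `CCCCCCCc1ccc(NC(=O)N[C@H](C)c2ccccc2)cc1`, 100%

Both compounds share a urea core carrying a phenyl ring on one side and a chiral phenylethyl group on the other. In an ADME assay on the whole organism with Oryza sativa as the target, tested at 1 uM (a lower number here means a stronger effect, a higher number a weaker effect of the compound at the concentration tested), compound 1 gives 101%, and compound 2 gives 100%. For the measured compounds named here, the only step between them, a number 1 percentage points lower from compound 1 to compound 2 (within the scatter), lengthens the chain and leaves the read-out unchanged, so compound 2 and compound 1 sit within the scatter of each other and neither can be called stronger.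

Compound 3, `CCOC(=O)c1ccc(NC(=O)N[C@H](C)c2ccccc2)cc1`, has not yet been measured in this assay. It differs from compound 2 in one place: ethoxycarbonyl in place of heptyl on an aromatic carbon. No measured step involves an ethoxycarbonyl group or removes an alkyl chain, so the step of a number 1 percentage points lower from compound 1 to compound 2 (within the scatter) is the only guide, and it bears on the change only loosely, having shown no shift beyond the scatter. With both known values close to full activity, the change is expected to produce a step of a number 2 percentage points lower from compound 2 to compound 3 (within the scatter), within the scatter. Compound 3 is therefore estimated at 98%, with a range from 85% to 106%.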

Compound 3, a percentage reported as activity, at one concentration (the size of the read-out at that concentration, not a potency): 100%
For compound 3 the middle estimate is 2 percentage points below the measured one; the range from low to high includes it.
By their numbers in this assay, from the lowest: compounds 2, 3 and 1 (each within the scatter of the next).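

The two earlier compounds differed only in the length of a saturated chain, so they could say nothing about a change in the kind of group at this position. Compound 3 does: in this assay, ethoxycarbonyl in place of heptyl gives no change at the digits printed from compound 2 to compound 3 (within the scatter) and ethoxycarbonyl in place of pentyl gives a number 1 percentage points lower from compound 1 to compound 3 (within the scatter) as the result. A group with oxygen atoms, a double bond outside aromatic rings and hydrogen-bond acceptors, on this aromatic carbon para to a large group, therefore gives a read-out within the scatter of both alkyl compounds, and the three cannot be ranked. Nothing available explains why the read-out behaves this way.

Going by these compounds, it remains open whether any group at this position can move the read-out beyond the scatter, for example an amine, a carboxylic acid or a chain longer than heptyl. The three compounds also share the phenylethyl side of the urea, so they cannot show whether a change there, such as a methoxy group on its ring, would matter.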